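From Bromo to 4-Methoxyphenyl on a Benzoxazolone Carbamate

The source may hold more compounds than are shown below. What is called first, only, known or untested is meant among the compounds shown, and "the series" means these compounds.

Compound 1 `O=C(NCCCCc1ccccc1)n1c(=O)oc2ccc(Br)cc21` was tested in an assay on HEK293 cells for inhibition of acid ceramidase (Homo sapiens), with a stated time of 10 min (on this read-out higher numbers stand for weaker inhibition and lower numbers for stronger inhibition), where it gave 22 nM. Compound 2 `O=C(NCCSCc1ccccc1)n1c(=O)oc2ccccc21` gave 65 nM in this assay, a weaker result, so compound 1 holds the lower of the two values. Compound 3 `COc1ccc(-c2ccc3oc(=O)n(C(=O)NCCCCc4ccccc4)c3c2)cc1` carries the change (4-methoxyphenyl in place of bromo on an aromatic carbon). Among the compounds with values here, no comparison between measured compounds bears on this change, so the expectation rests on compound 1 alone. A step of modest size toward stronger inhibition, or none beyond the scatter, is expected, a 1.5-fold lower number from compound 1 to compound 3 (0.17 log units; within the scatter). For compound 3 the value in this assay is estimated at 15 nM, within a range from 4 nM to 60 nM.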

Compound 3, half-maximal inhibitory concentration: 67 nM
Compound 3: middle estimate off by 4.5-fold (0.65 log units), on the low side; measured number above the stated range.
By their numbers in this assay, from the lowest: compound 1; then compounds 2 and 3 (each within the scatter of the next).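

In this assay, 4-methoxyphenyl in place of bromo on this aromatic carbon gives a 3.0-fold higher number from compound 1 to compound 3 (0.48 log units; beyond the scatter), a modest step toward weaker inhibition. Within the data shown here, this is the first reading of a change at this position, and it shows that a group with an added six-membered aromatic ring is tolerated here with some loss, while bromo remains the better of the two. No measurement shown here accounts for the step. On these data alone, what stays open is how a plain phenyl, without the methoxy, or a chloro on the same carbon would compare with compound 1.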